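The compounds below may be only part of what the source reports. "The series", "measured", "known", "first", "only" and "open" are said of these compounds alone.

Of the compounds shown here, two have numbers so far in a functional assay on HepG2 cells (Homo sapiens) for cytotoxicity, read by MTT assay, with a stated time of 24 h; on this read-out higher numbers stand for weaker inhibition and lower numbers for stronger inhibition. Compound 1 (`COc1cc(/C=C2\CN(S(=O)(=O)c3ccc(NC(C)=O)cc3)C/C(=C\c3ccccc3F)C2=O)cc(OC)c1OC`) gives 4750 nM, and compound 2 (`COc1cc(/C=C2\CN(S(=O)(=O)c3ccc(NC(C)=O)cc3)C/C(=C\c3ccc(C#N)cc3)C2=O)cc(OC)c1OC`) gives 2890 nM. These two values lie within the scatter of each other, so compound 2 cannot be told apart from compound 1 on the numbers shown.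

The next compound, compound 3 (`COc1cc(/C=C2\CN(S(=O)(=O)c3ccc(NC(C)=O)cc3)C/C(=C\c3cc(OC)c(OC)c(OC)c3)C2=O)cc(OC)c1`), differs from compound 2 by a single exchange, (3,5-dimethoxyphenyl in place of 4-cyanophenyl on a double-bonded chain carbon bound to a double-bonded ring carbon). In words, 3,5-dimethoxyphenyl stands in place of 4-cyanophenyl on a double-bonded chain carbon bound to a double-bonded ring carbon.

Among the compounds with values here, only one measured step bears on this place: a 1.6-fold lower number from compound 1 to compound 2 (0.22 log units; within the scatter), with 4-cyanophenyl in place of 2-fluorophenyl. Within the data shown here, no measured compound shows what 3,5-dimethoxyphenyl does at this place, so that single step is thin evidence. Among the measured compounds shown here, since the one exchange seen here stayed within the scatter, no change beyond the scatter is expected in this assay, and no direction is favoured.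

The expected step is a 1.1-fold higher number from compound 2 to compound 3 (0.06 log units; within the scatter). Compound 3 is estimated at 3300 nM, with an expected range from 1300 nM to 8000 nM.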

Compound 3, half-maximal inhibitory concentration: 4140 nM
Estimate against measurement, compound 3: 1.3-fold (0.10 log units) below, within the range that was stated.
By their numbers in this assay, from the lowest: compounds 2, 3 and 1 (each within the scatter of the next).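

In this assay, a third group at this place again stays within the scatter: the exchange to 3,5-dimethoxyphenyl gives a 1.4-fold higher number from compound 2 to compound 3 (0.16 log units; within the scatter) and, against the fluorinated compound, a 1.1-fold lower number from compound 1 to compound 3 (0.06 log units; within the scatter) in the same assay. Where the earlier pair offered one step, there are now three groups on a double-bonded chain carbon bound to a double-bonded ring carbon (2-fluorophenyl, 4-cyanophenyl and 3,5-dimethoxyphenyl), and no step among them lies beyond the scatter, even though the entering group has 10 heavy atoms and 2 hydrogen-bond acceptors against 8 heavy atoms and 1 hydrogen-bond acceptor in the group it replaces. No measurement at hand offers any reason for this sameness of the three numbers.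

As far as these compounds go, all three compounds carry a six-membered aromatic ring of carbon only at this place, so it remains open whether a group without such a ring, such as an amine, a carboxylic acid or a longer alkyl chain, would move the number beyond the scatter. The rest of the shared core is the same in compounds 1, 2 and 3, so these compounds say nothing about how changes elsewhere would read in this assay.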